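The compounds below may be only part of what the source reports. "The series", "measured", "known", "first", "only" and "open" are said of these compounds alone.

Of the compounds shown here, three have been measured so far in an in vivo ADME assay on the whole organism (strain BALB/c) for pharmacokinetics, with Mus musculus as the target, read by LC-MS, at a dose of 5 mg/kg by the oral route (a lower number here means that a smaller share of the oral dose reaches the circulation, a higher number that a larger share of the oral dose reaches the circulation), and they fall into two groups. Compound 1 `O=C(O)COc1ccc(Cl)cc1C#Cc1ccc(CO)cc1F` reaches 3% and stands apart from the other two. Compound 2 `CC(C)c1ccc(S(C)(=O)=O)cc1C#Cc1cc(C#N)ccc1OCC(=O)O` gives 26% as its value, and compound 3 `CC(C)c1ccc(S(C)(=O)=O)cc1C#Cc1cc(Cl)ccc1OCC(=O)O` gives 29% as its value. Compound 3 therefore sits level with compound 2 and clearly above compound 1.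

Compound 4 `Cc1ccc(S(C)(=O)=O)cc1C#Cc1cc(Cl)ccc1OCC(=O)O` differs from compound 3 in one place methyl in place of isopropyl on an aromatic carbon with methyl in place of isopropyl on an aromatic carbon, para to a methylsulfonyl group. Among the measured compounds shown here, the only measured step between compounds that differ in one place is a number 3 percentage points higher from compound 2 to compound 3 (within the scatter) and it stays within the scatter. That step exchanges cyano for chloro and leaves the isopropyl untouched, so it gives only a loose guide to the present change. Compound 1 differs from compound 3 in more than one place and offers no clean comparison. For the measured compounds named here, no measured step therefore gives a size for this exchange.

Taking compound 3 at 29% as the anchor, no step beyond the scatter is expected for compound 4 in this assay and no direction can be argued with confidence. The estimated change is a number 3 percentage points lower from compound 3 to compound 4 (within the scatter) and it is expected to stay within the scatter. The estimate for compound 4 is 26% with an expected range from 12% to 44% as its upper end.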

Compound 4, oral bioavailability: 49%
Beside the measured number, compound 4's estimate is 23 percentage points below it; measured number above the stated range.
By their numbers in this assay, from the lowest: compound 1; then compounds 2 and 3 (each within the scatter of the next); then compound 4.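

Among the compounds shown here, exchanging isopropyl for methyl on this aromatic carbon, ortho to a large group and para to a methylsulfonyl group, gives the first step beyond the scatter between compounds that differ in one place in this assay, with a number 20 percentage points higher from compound 3 to compound 4 (beyond the scatter). The earlier exchange of chloro for cyano, with a number 3 percentage points higher from compound 2 to compound 3 (within the scatter), left the reading within the scatter, so this position is the only one shown where a single change moves the number, and here the group goes from 3 heavy atoms to 1 heavy atom with no hydrogen-bond donor, hydrogen-bond acceptor or net charge entering or leaving. No measurement available here bears on what lies behind this step.

As far as these compounds go, whether the higher number belongs to methyl alone, or would also appear with a hydrogen, an ethyl group, a cyclopropyl group or a methoxy group on this carbon, stays open, as does whether it would carry over to the cyano partner of compound 4. The compounds shown also leave open how the reading would respond if a sulfonamide or an amide stood in place of the methylsulfonyl group.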